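A few compounds are considered here, and "the series" means these few. Any claim that something is new, unique, unknown or untested is made for them only; others in the source may bear on it.

Compound 1, with the structure `CCOC(=O)c1csc2nc(CN3CCN(Cc4ccccc4)CC3)c(-c3ccc(OC)cc3)n12`, gives 17100 nM in a functional assay on MCF7 cells (Homo sapiens) for antiproliferative activity, read by MTT assay, with a stated time of 72 h; on this read-out lower numbers stand for stronger inhibition and higher numbers for weaker inhibition. Compound 2, `CCOC(=O)c1csc2nc(CN3CCN(Cc4ccccc4)CC3)c(-c3ccc(Br)cc3)n12`, differs from it in a single place, namely (bromo in place of methoxy on an aromatic carbon), and in this assay compound 2 gives 51400 nM. That change made a 3.0-fold higher number from compound 1 to compound 2 (0.48 log units; beyond the scatter). Compound 3, whose structure is `COc1ccc(-c2c(CN3CCCCC3)nc3scc(C(=O)O)n23)cc1`, gives 62900 nM in this assay; how its core differs from the core of compound 1 is not broken down here, and its number is within the scatter of the number of compound 2 while standing beyond the scatter from compound 1.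

Compound 4, `O=C(O)c1csc2nc(CN3CCCCC3)c(-c3ccc(Br)cc3)n12`, has not yet been measured. It differs from compound 3 by bromo in place of methoxy on an aromatic carbon, the same change that separates compound 1 from compound 2, at the same place. On the strength of that single earlier step, the expected step for compound 4 is a 2.5-fold higher number from compound 3 to compound 4 (0.41 log units; beyond the scatter), beside the earlier step from compound 1 to compound 2. For compound 4 the estimated number in this assay is 160000 nM, expected to lie between 60000 nM and 450000 nM. That estimate rests on compound 3, which gives 62900 nM, and on one prior step only.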

Compound 4, half-maximal inhibitory concentration: 87500 nM
Compound 4: middle estimate off by 1.8-fold (0.26 log units), on the high side; the range from low to high includes it.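

Carried to the core of compound 3, the change from 4-methoxyphenyl to 4-bromophenyl gave a 1.4-fold higher number from compound 3 to compound 4 (0.14 log units; within the scatter) in this assay. Both steps run in the same direction, and the gap between them is no larger than repeated measurements would produce: the same change on two cores in this assay, a 3.0-fold higher number (0.48 log units; beyond the scatter) from compound 1 to compound 2 and a 1.4-fold higher number (0.14 log units; within the scatter) from compound 3 to compound 4, 2.2-fold (0.33 log units) apart, within the scatter of two such steps. The two cores therefore give no sign that the change behaves differently from one to the other, but two pairs cannot establish that it carries across this series in general, and the second step taken alone cannot be read as a real loss of activity.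

Only methoxy and bromo are shown at this place on the aromatic ring, so it remains open how a chloro group, a nitrile or an amine there would read in this assay. From the compounds shown here alone, it also remains open whether the step would hold on a core bearing an amide where compound 3 and compound 4 carry their carboxylic acid.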